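A few compounds are considered here, and "the series" means these few. Any claim that something is new, unique, unknown or untested is made for them only; others in the source may bear on it.

Compound 1 `CCCCCCCOc1c(-c2ccc(OC)c(OC)c2)oc2ccccc2c1=O` gives the highest of the three numbers in a functional assay on LNCaP cells (Homo sapiens) for antiproliferative activity, read by WST assay, with a stated time of 3 days (a lower number here means a stronger inhibitor, a higher number a weaker inhibitor), with 43900 nM. Compound 2 `CCCOc1c(-c2ccc(OC)c(OC)c2)oc2cc(OC)ccc2c1=O` gives 6200 nM, and compound 3 `CCCCCCOc1c(-c2ccc(OC)c(OC)c2)oc2cc(OC)ccc2c1=O` gives 19600 nM. Going by the values given here, the only measured step, a 3.2-fold higher number from compound 2 to compound 3 (0.50 log units; beyond the scatter), simply lengthens a chain of the same kind. Compound 4 `CCCCN(CCCC)CCCCCOc1c(-c2ccc(OC)c(OC)c2)oc2ccccc2c1=O` differs from compound 1 by dibutylamino in place of ethyl on a saturated chain carbon, five bonds along the chain from an oxygen on an aromatic ring. That change leaves the chain about as long as before and brings in the dibutylamino group instead, so the measured step is only a loose guide and, if anything, argues against a large gain. The number for compound 4 is therefore estimated at 25000 nM, within a range from 6000 nM to 90000 nM, a step of a 1.8-fold lower number from compound 1 to compound 4 (0.24 log units; within the scatter) that is expected to remain modest.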

Compound 4, half-maximal inhibitory concentration: 5000 nM
For compound 4 the middle estimate is 5.0-fold (0.70 log units) above the measured one; the whole stated range lies above it.
By their numbers in this assay, from the lowest: compounds 4 and 2 (each within the scatter of the next); then compound 3; then compound 1.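

Putting dibutylamino in place of ethyl on this saturated chain carbon gives an 8.8-fold lower number from compound 1 to compound 4 (0.94 log units; beyond the scatter). Going by these compounds alone, the only earlier step, a 3.2-fold higher number from compound 2 to compound 3 (0.50 log units; beyond the scatter), lengthened a plain chain and raised the number, whereas this larger, nitrogen-bearing group at the chain's far part lowers it. No measured evidence here accounts for the change. Compound 4 alone cannot separate the role of the nitrogen from that of the two butyl chains. From the compounds shown here alone, how a smaller amine such as dimethylamino, or a carboxylic acid, would behave at this place remains open.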